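Removing a methyl from compound 2

The source may report more compounds than this note shows. Statements on the series, on what has been measured and on what is new or still open speak of the compounds shown alone.

compound 1 `Cc1ccnc2nc(-c3cccc(Cl)c3)cc(O)c12` gives 813 nM
compound 2 `Cc1ccc2c(O)cc(-c3cccc(Cl)c3)nc2n1` gives 3800 nM

In a functional assay on cells (Panel breast (Carcinoma cell lines), Homo sapiens) for inhibition (on this read-out lower numbers stand for stronger inhibition of growth and higher numbers for weaker inhibition of growth), compound 2 stands at 3800 nM as the higher of the two numbers, and its gap to compound 1 lies beyond the scatter. Compound 3 `Oc1cc(-c2cccc(Cl)c2)nc2ncccc12` changes one place in compound 2: hydrogen in place of methyl on an aromatic carbon with hydrogen in place of methyl on an aromatic carbon. For the measured compounds named here, no measured pair shows this change alone, so no shift beyond the scatter is expected. The expected change is a 1.3-fold lower number from compound 2 to compound 3 (0.10 log units; within the scatter) in size and could go either way. For compound 3 the estimated value is 3000 nM with 900 nM to 10000 nM as its likely range.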

Compound 3, concentration for total growth inhibition: 1170 nM
For compound 3 the middle estimate is 2.6-fold (0.41 log units) above the measured one, and the stated range covers the measured number.
By their numbers in this assay, from the lowest: compounds 1 and 3 (each within the scatter of the next); then compound 2.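

In this assay, the methyl on the aromatic carbon next to the ring nitrogen carries a modest cost: replacing it with hydrogen gives (a 3.2-fold lower number from compound 2 to compound 3 (0.51 log units; beyond the scatter)). Replacing the methyl at its other place, in compound 1, gives (a 1.4-fold higher number from compound 1 to compound 3 (0.16 log units; within the scatter)), so only the methyl of compound 2 separates measurably from hydrogen. Nothing measured here explains this difference. Still open, as far as these compounds go, is whether an ethyl group, a methoxy group or an amine on the carbon next to the ring nitrogen would behave like methyl or like hydrogen in this assay.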